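Swapping the Dihydroxybenzyl of Compound 1 for a Carboxy Group

The compounds below may be only part of what the source reports. "The series", "measured", "known", "first", "only" and "open" are said of these compounds alone.

Compound 1 `Cc1cc(-c2c(F)cc3c(=O)c(Cc4c(O)cccc4O)cn(C4CC4)c3c2F)cc(C)n1` carries a 2,6-dihydroxybenzyl on the shared core, and in a functional assay on P388 cells (Mus musculus) for cytotoxicity (a higher number here means a weaker inhibitor, a lower number a stronger inhibitor), compound 1 gives 250 nM. Among the three compounds measured so far, compound 1 stands second highest; its nearest neighbour is compound 3 `Cc1cc(-c2c(F)cc3c(=O)c(Cc4ccc(O)cc4O)cn(C4CC4)c3c2F)cc(C)n1`, which in this assay gives 210 nM, and the step of a 1.2-fold lower number from compound 1 to compound 3 (0.08 log units; within the scatter) stays within the scatter. Compound 2 `Cc1cc(-c2c(F)cc3c(=O)c(Cc4ccccc4)cn(C4CC4)c3c2F)cc(C)n1`, bearing a plain phenyl on the same chain carbon, gives 7300 nM in this assay, and the step of a 29-fold higher number from compound 1 to compound 2 (1.47 log units; beyond the scatter) is large. Compound 4 `Cc1cc(-c2c(F)cc3c(=O)c(C(=O)O)cn(C4CC4)c3c2F)cc(C)n1` differs from compound 1 in one place: carboxy in place of 2,6-dihydroxybenzyl on an aromatic carbon. Going by the values given here, no measured step covers a carboxy on an aromatic carbon, so the only guide is a 29-fold higher number from compound 1 to compound 2 (1.47 log units; beyond the scatter), where stripping the hydroxyls alone cost much; removing the whole benzyl is a larger departure. Compound 4 is therefore expected to give a higher number, an estimated 15000 nM with a range from 3000 nM to 80000 nM, meaning an expected step of a 60-fold higher number from compound 1 to compound 4 (1.78 log units; beyond the scatter).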

Compound 4, half-maximal inhibitory concentration: 29000 nM
The estimate for compound 4 lay 1.9-fold (0.29 log units) below the measured number; the measured number falls inside the stated range.
By their numbers in this assay, from the lowest: compounds 3 and 1 (each within the scatter of the next); then compound 2; then compound 4.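

In this assay, the step of a 120-fold higher number from compound 1 to compound 4 (2.06 log units; beyond the scatter) and the step of a 140-fold higher number from compound 3 to compound 4 (2.14 log units; beyond the scatter) are both large, so replacing either dihydroxybenzyl group with carboxy costs more than removing the hydroxyls alone. The step of a 4.0-fold higher number from compound 2 to compound 4 (0.60 log units; beyond the scatter) is modest but beyond the scatter, which shows that even the unsubstituted benzyl gives a lower number at this aromatic carbon than carboxy does, although most of the difference among these compounds goes with the hydroxyls. Nothing available bears on why the number rises with this change.

The compounds shown leave open whether a benzyl with a single hydroxyl would be enough to keep the low numbers. They also leave open whether a primary amide or a methyl ester at this carbon would give a number closer to that of compound 4 or to that of compound 2.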